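A few compounds are considered here, and "the series" means these few. Any claim that something is new, unique, unknown or untested is made for them only; others in the source may bear on it.

Compound 1 `Cc1c(C(=O)N/N=C\c2c(O)cccc2F)oc2cccc(O)c12` gives 10800 nM in a functional assay on MGC-803 cells (Homo sapiens) for inhibition, read by MTT assay (on this read-out higher numbers stand for weaker inhibition and lower numbers for stronger inhibition), the highest of the three numbers at hand, although compound 2 `Cc1c(C(=O)N/N=C\c2cccc(F)c2O)oc2cccc(O)c12` with 8350 nM and compound 3 `Cc1ccc(O)c(/C=N\NC(=O)c2oc3cccc(O)c3c2C)c1` with 5990 nM both lie within the scatter of it. Compound 4 `Cc1c(C(=O)N/N=C\c2cccc(Br)c2O)oc2cccc(O)c12` differs from compound 1 in one place: 3-bromo-2-hydroxyphenyl in place of 2-fluoro-6-hydroxyphenyl on a carbon with a double bond to nitrogen. Among the measured compounds shown here, the measured steps that bear on this are a 1.3-fold lower number from compound 1 to compound 2 (0.11 log units; within the scatter), which puts 3-fluoro-2-hydroxyphenyl at the same position, and a 1.8-fold lower number from compound 1 to compound 3 (0.26 log units; within the scatter); both stay within the scatter, and no measured pair sets bromine against fluorine. Only a small step, if any beyond the scatter, is therefore expected: a 1.3-fold lower number from compound 1 to compound 4 (0.10 log units; within the scatter). Compound 4 is accordingly estimated at 8500 nM, within a range from 3500 nM to 20000 nM.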

Compound 4, half-maximal inhibitory concentration: 14200 nM
For compound 4 the middle estimate is 1.7-fold (0.22 log units) below the measured one; measured number inside the range.
By their numbers in this assay, from the lowest: compounds 3, 2, 1 and 4 (each within the scatter of the next, the first and the last beyond it).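

In this assay, the exchange of halogen can now be read directly: bromo in place of fluoro on an aromatic carbon gives a 1.7-fold higher number from compound 2 to compound 4 (0.23 log units; within the scatter), and the step from the 2-fluoro-6-hydroxyphenyl group gives a 1.3-fold higher number from compound 1 to compound 4 (0.12 log units; within the scatter), both within the scatter. Only a 2.4-fold higher number from compound 3 to compound 4 (0.37 log units; beyond the scatter) lies beyond it, a modest step and the first at this position to separate two groups, 3-bromo-2-hydroxyphenyl and 2-hydroxy-5-methylphenyl. From the compounds shown here alone, what an amine or a carboxylic acid on this phenyl ring would do remains open. Nothing at hand accounts for these steps.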